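A few compounds are considered here, and "the series" means these few. Any claim that something is new, unique, unknown or untested is made for them only; others in the source may bear on it.

Two compounds share a core built from a triazine carrying an amino group, a benzylamine arm and a phenyl ring bearing a hydroxymethyl group. Compound 1 `COc1cccc(-c2nc(N)nc(NCc3ccccc3)n2)c1CO` also carries a methoxy group on that phenyl ring, while compound 2 `Nc1nc(NCc2ccccc2F)nc(-c2ccccc2CO)n1` carries a fluorine on the benzyl arm instead. In a functional assay on cells for positive allosteric modulation of G-protein coupled receptor 68 (Homo sapiens), read by a luciferase reporter and cAMP accumulation, with a stated time of 30 min, at pH 6.8 and pH 8.3, in the presence of a further agent that is not named here (a lower number here means a less potent compound, a higher number a more potent compound, by a factor of ten per unit of this negative logarithm), compound 1 gives 4.16 and compound 2 gives 4.27. The gap between these two numbers lies within the usual scatter of the measurement, so compound 2 and compound 1 cannot be told apart on this evidence; compound 2 is simply the one from which the next step is taken.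

Compound 3 `Nc1nc(NCc2cccc(Cl)c2)nc(-c2ccccc2CO)n1` arises from compound 2 by a single change: 3-chlorophenyl in place of 2-fluorophenyl on a saturated chain carbon bound to a nitrogen on an aromatic ring. For the measured compounds named here, no pair of measured compounds that differ in only this way is available, so the step has no direct precedent here. A swap of one halogen-bearing benzyl group for another, at the same point of attachment, is expected to move the result little, if at all, in either direction. Compound 3 is therefore estimated to give 4.3, with a likely range from 3.8 to 4.8. This estimate corresponds to a step of a number 0.03 log units higher from compound 2 to compound 3 (within the scatter), which is not expected to exceed the scatter.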

Compound 3, negative logarithm of the antagonist equilibrium constant: 4.97
The estimate for compound 3 lay 0.67 log units below the measured number, outside the stated range (above it).
By their numbers in this assay, from the lowest: compounds 1 and 2 (each within the scatter of the next); then compound 3.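

In this assay, the benzyl arm proves able to move the read-out: replacing 2-fluorophenyl with 3-chlorophenyl on a saturated chain carbon bound to a nitrogen on an aromatic ring gives a number 0.70 log units higher from compound 2 to compound 3 (beyond the scatter). Compound 1 and compound 2 differ in more than one place, so they could not show this effect of a single change. The counts for the two groups match in heavy atoms, aromatic ring, hydrogen-bond donors, hydrogen-bond acceptors and net charge, so those counts do not separate them, and no measurement at hand explains the gain.

On these data alone, the change swaps the halogen and alters its place on the ring in one step, so it remains open whether the gain goes with chlorine itself, with where the halogen sits, or with both. As far as these compounds go, it is also open how the number would respond to a bromine or a trifluoromethyl group in place of that chlorine, or to an amine or a carboxylic acid in place of the hydroxymethyl group on the other phenyl ring.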